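Benzyl for Fluorophenyl on the Triazole Nitrogen

The source may hold more compounds than are shown below. What is called first, only, known or untested is meant among the compounds shown, and "the series" means these compounds.

Compound 2 `O=c1nc2oc(CCCCl)cc2cn1Cc1cn(-c2ccc(F)cc2)nn1` is the point of departure. In a functional assay on CFPAC-1 cells (Homo sapiens) for antiproliferative activity, read by MTT assay, with a stated time of 72 h (on this read-out lower numbers stand for stronger inhibition and higher numbers for weaker inhibition), compound 2 gives 6490 nM, the lowest of the two numbers that have been measured. Its nearest neighbour is compound 1 `O=c1nc2oc(CCCCl)c(C#CCCCCCl)c2cn1Cc1cn(-c2ccc(F)cc2)nn1`, which carries a 6-chlorohex-1-yn-1-yl group on the core and in this assay gives 95800 nM; the step of a 15-fold lower number from compound 1 to compound 2 (1.17 log units; beyond the scatter) goes with hydrogen in place of 6-chlorohex-1-yn-1-yl on an aromatic carbon. Compound 3 `CCCCCCC#Cc1c(CCCCCC)oc2nc(=O)n(Cc3cn(-c4ccc(F)cc4)nn3)cc12`, which bears longer chains on the core, reaches only a limit in this assay, > 100000 nM, so that (the limit of > 100000 nM in this assay, at which 1 of the 3 values shown sits).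

Compound 4 `O=c1nc2oc(CCCCl)cc2cn1Cc1cn(Cc2ccccc2)nn1` differs from compound 2 by benzyl in place of 4-fluorophenyl on an aromatic nitrogen. Within the data shown here, no measured step bears on this change: the one step that has been measured concerns the chain on the core and not the group on the triazole nitrogen, and compound 3 contributes a limit rather than a number. With nothing pointing in either direction, no step beyond the scatter is expected from compound 2 to compound 4 in this assay. The estimate for compound 4 in this assay is 8000 nM, with a range from 2500 nM to 30000 nM. That estimate corresponds to an expected step of a 1.2-fold higher number from compound 2 to compound 4 (0.09 log units; within the scatter).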

Compound 4, half-maximal inhibitory concentration: 23500 nM
Compound 4: the middle estimate sits 2.9-fold (0.47 log units) below what was measured, and the stated range covers the measured number.
By their numbers in this assay, from the lowest: compound 2; then compound 4; then compound 1. At a limit, above all of these: compound 3.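

The group on this aromatic nitrogen proves able to move the number: in this assay, benzyl in place of 4-fluorophenyl goes with a 3.6-fold higher number from compound 2 to compound 4 (0.56 log units; beyond the scatter). Among these compounds, the only earlier step concerned a group on the core, so this is the first measured sign that the substituent at this nitrogen also matters, although the change is smaller than the step seen on the core. The two groups match in what can be counted, each with 7 heavy atoms and one six-membered aromatic ring of carbon only, yet they are not interchangeable here, and nothing measured among these compounds gives a reason for the step.

The change removes the fluorine and adds a carbon link to the ring at the same time, so the compounds shown do not separate the two; an unsubstituted phenyl or a 4-fluorobenzyl group on this nitrogen would do so. Also open, on these data alone, is whether a longer chain such as phenethyl would go further in the same direction, and whether the step holds on a core carrying the 6-chlorohex-1-yn-1-yl group of compound 1.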